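Methoxymethyl in place of 1-methylpiperidin-4-yl on a carbonyl carbon

The source may report more compounds than this note shows. Statements on the series, on what has been measured and on what is new or still open speak of the compounds shown alone.

Measured compounds in a functional assay on KB cells (Homo sapiens) for antiproliferative activity, read by sulforhodamine B assay, with a stated time of 3 days (a lower number here means a stronger inhibitor of growth, a higher number a weaker inhibitor of growth), are these
Compound 1 `O=C(Nc1ccccn1)c1cccc(Nc2ncc(F)c(Nc3ccc(F)cc3)n2)c1` gives 20000 nM
Compound 2 `O=C(Nc1cccc(Nc2ncc(F)c(Nc3ccc(F)cc3)n2)c1)c1cccc([N+](=O)[O-])c1` gives 15100 nM
Compound 3 `CN1CCC(C(=O)Nc2cccc(Nc3ncc(F)c(Nc4ccc(F)cc4)n3)c2)CC1` gives 1700 nM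

Compound 3 stands lowest of the three in this assay at 1700 nM and is the strongest inhibitor of growth among them. One measured step bearing on it is a 12-fold lower number from compound 1 to compound 3 (1.07 log units; beyond the scatter) and the other is an 8.9-fold lower number from compound 2 to compound 3 (0.95 log units; beyond the scatter) with 1-methylpiperidin-4-yl entering in both. The next structure is compound 4 `COCC(=O)Nc1cccc(Nc2ncc(F)c(Nc3ccc(F)cc3)n2)c1` and the change to it reads methoxymethyl in place of 1-methylpiperidin-4-yl on a carbonyl carbon so that methoxymethyl stands in place of 1-methylpiperidin-4-yl on a carbonyl carbon. Within the data shown here, no measured step shows methoxymethyl itself. Compound 2 at 15100 nM and compound 1 at 20000 nM both lack the group that compound 4 gives up, so a move back towards higher numbers is expected, of modest size and smaller than those two steps. The expected change is a 2.9-fold higher number from compound 3 to compound 4 (0.47 log units; beyond the scatter) in this estimate. Compound 4 is estimated at 5000 nM as a middle value, with an expected range from 1800 nM to 18000 nM around it.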

Compound 4, concentration for 50% growth inhibition: 6250 nM
For compound 4 the middle estimate is 1.3-fold (0.10 log units) below the measured one; measured number inside the range.
By their numbers in this assay, from the lowest: compound 3; then compound 4; then compounds 2 and 1 (each within the scatter of the next).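

In this assay, the carbonyl carbon on the amide-type nitrogen now carries an open chain as well as a ring, and the change gives a 3.7-fold higher number from compound 3 to compound 4 (0.57 log units; beyond the scatter), so losing 1-methylpiperidin-4-yl costs growth inhibition beyond the scatter. Methoxymethyl still does better than the aromatic groups, with a 2.4-fold lower number from compound 2 to compound 4 (0.38 log units; beyond the scatter) when it replaces 3-nitrophenyl and a 3.2-fold lower number from compound 1 to compound 4 (0.51 log units; beyond the scatter) when ((methoxymethyl)carbonyl)amino replaces (pyridin-2-yl)carbamoyl, so a number lower than those of these two compounds does not require 1-methylpiperidin-4-yl. No measurement at hand explains this ordering.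

The compounds shown do not tell whether the ring or its nitrogen carries the advantage of compound 3 over compound 4. A cyclohexyl group would keep the ring without the amine, and a dimethylaminomethyl group would keep an amine without the ring.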